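The source may hold more compounds than are shown below. What is called first, only, known or untested is meant among the compounds shown, and "the series" means these compounds.

In a functional assay on MCF7 cells (Homo sapiens) for cytotoxicity, read by MTT assay, with a stated time of 6 days (on this read-out higher numbers stand for an effect only at larger amounts of compound and lower numbers for an effect already at smaller amounts), the three measured compounds stand as follows, each at a limit of the assay rather than at a number:

Compound 1, `COc1cc(-c2oc3ccccc3c(=O)c2C(=O)O)cc(OC)c1OC`: > 25 ug/mL
Compound 2, `COc1cc(OC)cc(-c2oc3ccccc3c(=O)c2C(=O)O)c1`: > 25 ug/mL
Compound 3, `O=C(O)c1c(-c2ccc([N+](=O)[O-])cc2)oc2ccccc2c1=O`: > 25 ug/mL

Compound 2 differs from compound 1 by a single change, (methoxy in place of hydrogen on an aromatic carbon). The step that the two limits leave unreadable from compound 2 to compound 1 cannot be sized, since both ends of it are limits. Compound 3 shares the carboxylic-acid-bearing core with compound 2, but the difference between the two cores is not broken down here.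

The unmeasured compound 4, `COc1ccc2oc(-c3ccc([N+](=O)[O-])cc3)c(C(=O)O)c(=O)c2c1`, is reached from compound 3 by the same kind of change, (methoxy in place of hydrogen on an aromatic carbon). It is not the same change: in compound 1 the methoxy enters on a six-membered aromatic ring of carbon only, ortho to two methoxy groups and para to a large group, whereas in compound 4 it enters on a ring that is part of a fused or bridged system of two rings, meta to a fused ring and para to a fused ring.

What the measured pair shows is the limit of > 25 ug/mL in this assay, at which 3 of the 3 values shown sit, so no movement away from the limit has yet been seen with this kind of change. On that basis compound 4 is expected to stay near the same limit, and the step that the limit leaves unreadable from compound 3 to compound 4 is estimated to be small. Compound 4 is therefore estimated at 40 ug/mL, within a range from 15 ug/mL to 150 ug/mL.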

Compound 4, concentration for half-maximal effect: 15.9 ug/mL
For compound 4 the middle estimate is 2.5-fold (0.40 log units) above the measured one; the measured number falls inside the stated range.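

In this assay, methoxy in place of hydrogen on an aromatic carbon of a ring that is part of a fused or bridged system of two rings gives an at least 1.5-fold lower number from compound 3 to compound 4 (0.19 log units; that floor lies within the scatter); compound 3 stands only at a limit, so the true size of this step is not known, and the floor alone does not clear the usual scatter. Within the data shown here, compound 4 is the only one of the four compounds that gives a number, while the others stay at the limit: the limit of > 25 ug/mL in this assay, at which 3 of the 4 values shown sit. The other step of this kind, on the core of compound 2, cannot be read, and the methoxy there enters at a different place, so the compounds shown offer no case in which the same change can be sized on two cores, and they do not show that it carries from one core to another.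

On these data alone, it remains open whether methoxy at the place it holds in compound 4 would also yield a number on the core of compound 1 or compound 2. As far as these compounds go, it also remains open whether an amine, a hydroxyl or a longer chain such as ethoxy at that same place would give a reading like that of compound 4.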